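A Longer Chain on an Aromatic Nitrogen of Compound 1

A few compounds are considered here, and "the series" means these few. Any claim that something is new, unique, unknown or untested is made for them only; others in the source may bear on it.

Measured so far:
compound 1, `CN(C)CCCNC(=O)c1cc(NC(=O)c2cc(NC(=O)c3cc(NC(=N)c4ccccc4)cn3C)cn2C)cn1C`: 11 degrees C
compound 2, `CC(C)CCc1sc(NC(=O)c2cc(NC(=O)c3cc(NC(=N)c4cccc(Cl)c4)cn3C)cn2C)nc1C(=O)NCCCN(C)C`: 5 degrees C

Of the compounds shown here, two have been measured in an assay on nucleic acid for binding affinity to Salmon testes DNA (Salmonidae), tested at 10 uM; a lower number here means that the compound stabilises the target less, a higher number that the compound stabilises the target more against heat. Compound 1 gives 11 degrees C and stands highest of the two. Compound 2 gives 5 degrees C, a number that lies beyond the usual scatter below compound 1; the two structures differ in several places at once, so only the two values themselves can be compared.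

The unmeasured compound 3, `CC(C)CCn1cc(NC(=O)c2cc(NC(=O)c3cc(NC(=N)c4ccccc4)cn3C)cn2C)cc1C(=O)NCCCN(C)C`, keeps the whole of compound 1 and changes it in one place: isobutyl in place of hydrogen on a saturated chain carbon bound to an aromatic nitrogen. In this assay, among the compounds with values here, no single-change step between measured compounds exists to lean on. With compound 1 at 11 degrees C as the starting point, a modest drop in melting-temperature shift is expected from adding the isobutyl, of a size close to the scatter rather than far beyond it.

Compound 3 is therefore estimated at 9 degrees C, with a range from 6 degrees C to 12 degrees C, which corresponds to an expected step of a number 2.0 degrees C lower from compound 1 to compound 3 (beyond the scatter).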

Compound 3, shift of the target's melting temperature: 8 degrees C
For compound 3 the middle estimate is 1.0 degrees C above the measured one; low and high end bracket the measured number.
By their numbers in this assay, from the lowest: compound 2; then compound 3; then compound 1.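

In this assay, isobutyl in place of hydrogen on a saturated chain carbon bound to an aromatic nitrogen gives a number 3.0 degrees C lower from compound 1 to compound 3 (beyond the scatter). Within the data shown here, this is the only comparison here that isolates a single place, as compound 1 and compound 2 differ in several places at once, so it ties a change in the melting-temperature shift to this position for the first time. The position tolerates the added isobutyl without losing the shift, for compound 3 still reaches 8 degrees C in this assay, yet the fall lies beyond the scatter, so the change is not neutral. Nothing at hand accounts for the fall in the number.

Among these compounds, the single step leaves open whether the fall follows the length of the chain, its branching or simply the presence of any larger group at this place, which a shorter ethyl chain, an unbranched longer chain or a chain ending in an amine or a carboxylic acid would help to separate. It also leaves open whether the same change would cost as much on any of the other aromatic nitrogens of the core of compound 1.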